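Ethyl to tert-butyl on the urea of compound 2

This account rests on a few compounds, and the source may have more. Where it says the series, first, only, none or still open, it means among the compounds named here.

Measured compounds:
- compound 1, `CCc1ccc(NC(=O)N[C@H](C)c2ccccc2)cc1`: 44%
- compound 2, `CCc1ccc(NC(=O)N[C@@H](C)c2ccccc2)cc1`: 91%

Of the compounds shown here, two have been measured in an ADME assay on the whole organism with Oryza sativa as the target, tested at 10 uM (a higher number here means a weaker effect of the compound at the concentration tested, a lower number a stronger effect), and both share one urea core that carries an ethyl group on its aromatic ring. They differ only in how the saturated chain carbon is drawn, and that single difference goes with the step of a number 47 percentage points higher from compound 1 to compound 2 (beyond the scatter). Compound 2 stands highest of the two numbers, with compound 1 the nearest at 44%.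

Compound 3, `C[C@H](NC(=O)Nc1ccc(C(C)(C)C)cc1)c1ccccc1`, is not yet measured. Compared with compound 2 the change is tert-butyl in place of ethyl on an aromatic carbon. Going by the values given here, the only measured step, the one from compound 1 to compound 2, concerns configuration alone and says nothing about the size of the alkyl group; so no measured step bears on this change, and the expected size of the step in this assay rests on the value of compound 2 alone.

Compound 3 is therefore expected to lie near compound 2, at 86%, within 62% to 100%, a step of a number 5 percentage points lower from compound 2 to compound 3 (within the scatter) that is estimated to stay within the scatter.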

Compound 3, a percentage reported as activity, at one concentration (the size of the read-out at that concentration, not a potency): 64%
Beside the measured number, compound 3's estimate is 22 percentage points above it; low and high end bracket the measured number.
By their numbers in this assay, from the lowest: compound 1; then compound 3; then compound 2.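

Moving from ethyl to tert-butyl on an aromatic carbon, para to a large group, matters in this assay: the change gives a number 27 percentage points lower from compound 2 to compound 3 (beyond the scatter), which means a stronger effect at the concentration tested. Going by these compounds alone, until now the only measured step concerned the configuration at the saturated chain carbon, so this is the first sign that the alkyl group on the aromatic ring also moves the read-out, and by more than repeated measurements would usually scatter. Nothing available explains why replacing ethyl with tert-butyl has this effect.

With only ethyl and tert-butyl shown at this position, two groups cannot establish a trend, so it remains open how this assay would respond to an isopropyl group, a longer chain such as n-butyl, or an amine or carboxylic acid on the same carbon. As far as these compounds go, it is also open whether tert-butyl would produce a similar step in the configuration of compound 1, where the ethyl compound sits at a much lower number, or whether the two changes would not simply add up.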